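A Nitro Group on the Phenyl Arm of Compound 1

The source may report more compounds than this note shows. Statements on the series, on what has been measured and on what is new or still open speak of the compounds shown alone.

Compound 1 `COc1cc(-c2cc(-c3ccccc3)nc(-c3ccccc3)n2)cc(OC)c1OC` is the parent of a small series tested in a functional assay on MDA-MB-231 cells (Homo sapiens) for inhibition, read by MTT assay, with a stated time of 48 h; a higher number here means a weaker inhibitor, a lower number a stronger inhibitor. In that assay compound 1 gives 5870 nM, the highest of the three numbers recorded. Compound 2 `COc1cc(-c2cc(-c3cccc4ccccc34)nc(-c3ccccc3)n2)cc(OC)c1OC` gives 3240 nM, and compound 3 `COc1cc(-c2cc(-c3ccc(C)cc3)nc(-c3ccccc3)n2)cc(OC)c1OC` gives 5110 nM. The steps away from compound 1 are small: a 1.8-fold lower number from compound 1 to compound 2 (0.26 log units; within the scatter) and a 1.1-fold lower number from compound 1 to compound 3 (0.06 log units; within the scatter); between the two analogues, a 1.6-fold higher number from compound 2 to compound 3 (0.20 log units; within the scatter). All three steps lie within the scatter, so the numbers for compound 1, compound 2 and compound 3 cannot be told apart.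

Compound 4 `COc1cc(-c2cc(-c3cccc([N+](=O)[O-])c3)nc(-c3ccccc3)n2)cc(OC)c1OC` differs from compound 1 in one place: nitro in place of hydrogen on an aromatic carbon. The change sits on the same phenyl ring that carries the methyl in compound 3 and that is replaced by naphthalen-1-yl in compound 2. For the measured compounds named here, no measured step involves a nitro group, so there is no direct precedent; the two steps that alter this ring both stay within the scatter. One therefore expects no step beyond the scatter in this assay, in either direction, and estimates compound 4 at 4800 nM, with a range from 2000 nM to 11000 nM. That estimate corresponds to an expected step of a 1.2-fold lower number from compound 1 to compound 4 (0.09 log units; within the scatter), inside the usual spread of repeats.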

Compound 4, half-maximal inhibitory concentration: 2440 nM
The estimate for compound 4 lay 2.0-fold (0.29 log units) above the measured number; measured number inside the range.
By their numbers in this assay, from the lowest: compounds 4, 2, 3 and 1 (each within the scatter of the next, the first and the last beyond it).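

In this assay, for the compounds shown here, the 3-nitrophenyl arm gives the first step on this ring that clears the usual scatter (a 2.4-fold lower number from compound 1 to compound 4 (0.38 log units; beyond the scatter)), a modest change, whereas neither the methyl of compound 3 nor the naphthalen-1-yl of compound 2 moved the number measurably from that of compound 1. The same arm also separates modestly from the 4-methylphenyl arm (a 2.1-fold lower number from compound 3 to compound 4 (0.32 log units; beyond the scatter)), but it cannot be told apart from the naphthalen-1-yl arm (a 1.3-fold lower number from compound 2 to compound 4 (0.12 log units; within the scatter)), so this ring now shows a small measurable response to substitution rather than a clear ranking among all its variants. Nothing available accounts for this modest step.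

The compounds shown leave open whether the step depends on the nitro group standing at this place on the ring, or whether it would persist with the group placed elsewhere on that ring. They also leave open whether an amine, a carboxylic acid or a nitrile at this same place would give a similar number, and whether the second phenyl arm of the shared core responds to such a change at all.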